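This account rests on a few compounds, and the source may have more. Where it says the series, first, only, none or still open, it means among the compounds named here.

Measured compounds:
Compound 1 `CC(=O)NC[C@H]1CN(c2ccc(OC[C@@H](O)CNc3ccccc3)c(F)c2)C(=O)O1` gives 1.42 in a physicochemical assay for lipophilicity, read by HPLC; on this read-out lower numbers stand for lower lipophilicity and higher numbers for higher lipophilicity.
Compound 2 `CC(=O)NC[C@H]1CN(c2ccc(OC[C@H](O)CNc3ccccc3)c(F)c2)C(=O)O1` gives 0.59 in this assay.

Going by the values given here, compound 2 stands lowest of the two numbers so far; its only neighbour is compound 1, and the step between them is a number 0.83 log units lower from compound 1 to compound 2 (beyond the scatter). That step rests on the fact that compounds 1 and 2 differ only in the configuration as drawn alone, the two compounds being identical in atoms and bonds.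

Compound 3 `CC(=O)NC[C@H]1CN(c2ccc(OC[C@H](O)CNc3ccc(C#N)cc3)c(F)c2)C(=O)O1` is not yet measured. It differs from compound 2 by cyano in place of hydrogen on an aromatic carbon. Among the compounds with values here, the one measured step is the configurational one from compound 1 to compound 2; no measured pair shows a cyano group entering, or any other change of substitution on the anilino ring, so that step offers no guide to the size of the change from compound 2 to compound 3. With nothing in the measured steps to lean on, the expectation for compound 3 is a small downward step, a number 0.34 log units lower from compound 2 to compound 3 (beyond the scatter), expected to lie within or only just beyond the scatter. Compound 3 is accordingly expected to give about 0.25 in this assay, in the range -0.35 to 0.85.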

Compound 3, partition coefficient: 1.29
For compound 3 the middle estimate is 1.04 log units below the measured one; measured number outside the range, above it.
By their numbers in this assay, from the lowest: compound 2; then compounds 3 and 1 (each within the scatter of the next).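

In this assay, going by these compounds alone, the carbon para to a large group on the anilino ring responds to substitution: cyano in place of hydrogen there gives a number 0.70 log units higher from compound 2 to compound 3 (beyond the scatter) and so brings the first measured change of substitution on this ring. On the printed grading this phenyl to 4-cyanophenyl change is a modest step, the same grade as the configurational change, which gives a number 0.83 log units lower from compound 1 to compound 2 (beyond the scatter) and runs in the opposite direction on the read-out. Within the data shown here, the only fact on record concerns the configurational pair and does not bear on the cyano step, so the series offers no account of that step.

Going by these compounds, it remains open whether cyano moves the number by a similar step on the configuration drawn in compound 1, where the chain stereocentre is drawn S rather than R. It also remains open whether the step belongs to cyano in particular or would recur with another group on the same aromatic carbon, such as a carboxylic acid, an amine or a methoxy group.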